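A few compounds are considered here, and "the series" means these few. Any claim that something is new, unique, unknown or untested is made for them only; others in the source may bear on it.

Three analogues share one core and differ only at a single aromatic carbon of the fused ring. In an ADME assay on MT4 cells (Homo sapiens) for cytotoxicity, read by MTT assay, with a stated time of 5 days (a higher number here means that more compound is tolerated, a lower number that less compound is tolerated), compound 3 `O=[N+]([O-])c1ccc(-c2nnc(-c3cccnc3)n2Nc2nc3ccc(Cl)cc3s2)cc1` gives 53.7 ug/mL, the higher of the two numbers recorded; compound 2 `COc1ccc2nc(Nn3c(-c4ccc([N+](=O)[O-])cc4)nnc3-c3cccnc3)sc2c1` gives 12.9 ug/mL, and the step of a 4.2-fold higher number from compound 2 to compound 3 (0.62 log units; beyond the scatter) lies beyond the scatter. Compound 1 `O=[N+]([O-])c1ccc(-c2nnc(-c3cccnc3)n2Nc2nc3ccc(F)cc3s2)cc1` gives only a limit, >= 108 ug/mL. Compound 4 `O=[N+]([O-])c1ccc(-c2nnc(-c3cccnc3)n2Nc2nc3cc(Cl)c(Cl)cc3s2)cc1` differs from compound 3 by chloro in place of hydrogen on an aromatic carbon, ortho to a chloro group. For the measured compounds named here, none of the measured steps adds a second substituent; the steps of an at least 2.0-fold lower number from compound 1 to compound 3 (0.30 log units; that floor lies within the scatter) and an at least 8.3-fold lower number from compound 1 to compound 2 (0.92 log units; beyond the scatter) swap one group for another and bear only loosely on this change. A somewhat lower number is expected for compound 4, the step of a 1.7-fold lower number from compound 3 to compound 4 (0.22 log units; within the scatter) staying modest. Compound 4 is therefore estimated at 32 ug/mL, between 12 ug/mL and 90 ug/mL.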

Compound 4, half-maximal cytotoxic concentration: 68.7 ug/mL
For compound 4 the middle estimate is 2.1-fold (0.33 log units) below the measured one; measured number inside the range.
By their numbers in this assay, from the lowest: compound 2; then compounds 3 and 4 (each within the scatter of the next). At a limit, above all of these: compound 1.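

Chloro in place of hydrogen on an aromatic carbon, ortho to a chloro group, is the first added substituent in this set, and in this assay it gives a 1.3-fold higher number from compound 3 to compound 4 (0.11 log units; within the scatter). This position therefore takes a second chloro with no shift that can be told from the scatter, which the earlier swaps of one group for another could not show.

From the compounds shown here alone, whether a larger or different group here, such as an amine or a carboxylic acid, would behave alike stays open. Compound 1 remains a limit, not a number, so the top of this set stays undefined: the limit of >= 108 ug/mL in this assay, at which 1 of the 4 values shown sits.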